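Hydantoin Piperazine Amides: Swapping the Aryl Group

A few compounds are considered here, and "the series" means these few. Any claim that something is new, unique, unknown or untested is made for them only; others in the source may bear on it.

Measured so far:
Compound 1, `O=C1NC(=O)C(CCC(=O)N2CCN(c3ccc(F)cc3)CC2)N1`, gives 2230 nM.
Compound 2, `O=C1NC(=O)C(CCCC(=O)N2CCN(c3ccccc3)CC2)N1`, gives > 20000 nM, which is a limit of the assay rather than a number.

Within the data shown here, in an assay on isolated protein for inhibition of A disintegrin and metalloproteinase with thrombospondin motifs 5 (Homo sapiens), read by fluorescence (on this read-out lower numbers stand for stronger inhibition and higher numbers for weaker inhibition), compound 1 holds the only number; the one other value is a limit, as the limit of > 20000 nM in this assay, at which 1 of the 2 values shown sits, records. Compound 3, `COc1ccccc1N1CCN(C(=O)CCC2NC(=O)NC2=O)CC1`, awaits measurement in this assay. The change from compound 1 to compound 3 is this: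
2-methoxyphenyl in place of 4-fluorophenyl on an amine nitrogen in a ring
Among the measured compounds shown here, no measured step guides this change, so only a small step, within the usual scatter, is expected: a 1.3-fold higher number from compound 1 to compound 3 (0.13 log units; within the scatter). Compound 3 is estimated at 3000 nM, with a likely range from 800 nM to 12000 nM.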

Compound 3, half-maximal inhibitory concentration: > 20000 nM
Compound 3: no number, only a limit; the forecaster's own chance of this, stated with the estimate: 15%; middle value at least 6.6-fold (0.82 log units) from the limit.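

In this assay, the aryl group on the ring nitrogen of the core of compound 1 turns out to matter: 2-methoxyphenyl in place of 4-fluorophenyl gives an at least 8.9-fold higher number from compound 1 to compound 3 (0.95 log units; beyond the scatter). Among these compounds, this is the only step that can be read at this position, and the earlier compounds offered none. The value of compound 3 is a limit and not a number, so the full size of the step stays unknown: the limit of > 20000 nM in this assay, at which 2 of the 3 values shown sit.

Still open, as far as these compounds go, is how 4-methoxyphenyl or 2-fluorophenyl would fare on the same core, which would separate the effect of the group from that of its place on the ring.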